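A few compounds are considered here, and "the series" means these few. Any claim that something is new, unique, unknown or untested is made for them only; others in the source may bear on it.

Compound 1 `CCCCCCCCCCCc1cc2cn(COCCO)c(=O)nc2o1` carries an undecyl chain on the shared core. In a functional assay on HEL cells (Homo sapiens), read by microscopy (on this read-out higher numbers stand for lower toxicity in this test and lower numbers for higher toxicity in this test), compound 1 gives 80000 nM. Compound 2 `CCCCCCCc1cc2cn(COCCO)c(=O)nc2o1` differs from it by hydrogen in place of butyl on a saturated chain carbon, seven bonds along the chain from an aromatic carbon, and in this assay compound 2 gives 400000 nM, so the shorter chain changed the reading by a 5.0-fold higher number from compound 1 to compound 2 (0.70 log units; beyond the scatter).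

Compound 3 `CCCCCCCCC#Cc1cc2cn(COCCO)c(=O)nc2o1` has a chain joined to the core through a triple bond; how its core differs from that of compound 1 is not broken down here. In this assay compound 3 gives only a limit of the assay, >= 20000 nM.

Compound 4 `CCCCC#Cc1cc2cn(COCCO)c(=O)nc2o1` has not yet been measured in this assay. It differs from compound 3 by hydrogen in place of butyl on a saturated chain carbon, four bonds along the chain from a triple-bonded carbon, which is the same kind of change as from compound 1 to compound 2, though the place differs: seven bonds along the chain from an aromatic carbon there, four bonds along the chain from a triple-bonded carbon here.

Because compound 3 already sits at the limit of >= 20000 nM in this assay, at which 1 of the 3 values shown sits, the step from compound 3 to compound 4 is expected to read a step that the limit leaves unreadable from compound 3 to compound 4, and compound 4 is expected to give about 100000 nM, quite possibly again only a limit.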

Compound 4, minimum cytotoxic concentration: > 100000 nM
Compound 4 was reported as a limit; the forecaster's own chance of this, stated with the estimate: 60%; the middle value sits exactly at the limit.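

In this assay compound 4 gives > 100000 nM, which is a limit of the assay. Compound 3 also gives only a limit, >= 20000 nM. Neither the step from compound 3 to compound 4 nor the step from compound 2 to compound 4 can be read. The compounds shown leave open how chain length changes the reading when the chain is joined through a triple bond.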